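Swapping Bromo for Fluoro on Compound 2

The source may report more compounds than this note shows. Statements on the series, on what has been measured and on what is new or still open speak of the compounds shown alone.

compound 1 `COc1cc(OC)c(OC)cc1/C=C/COC(=O)/C=C/c1cc(OC)c(OC)c(OC)c1OC` gives 42.2 mg/kg
compound 2 `COc1cc(OC)c(OC)cc1/C=C/COC(=O)/C=C/c1ccc(Br)cc1` gives 105 mg/kg
compound 3 `COc1cc(OC)c(OC)cc1/C=C/COC(=O)/C=C/c1cc(OC)c(OC)c(OC)c1` gives 85.5 mg/kg

In a functional assay on the whole organism (strain Kunming) with Mus musculus as the target, in the formalin test, with a stated time of 0.5 h (on this read-out lower numbers stand for an effect already at smaller amounts and higher numbers for an effect only at larger amounts of compound), compound 2 gives 105 mg/kg. Compound 3 gives 85.5 mg/kg, and compound 1 gives 42.2 mg/kg. Compound 2 lies within the scatter of compound 3, and the gap between compound 2 and compound 1 is beyond the scatter. Compound 4 `COc1cc(OC)c(OC)cc1/C=C/COC(=O)/C=C/c1ccc(F)cc1` changes compound 2 in one place: fluoro in place of bromo on an aromatic carbon. Among the compounds with values here, the only measured step, a 2.0-fold higher number from compound 1 to compound 3 (0.31 log units; beyond the scatter), is modest and concerns hydrogen in place of methoxy on an aromatic carbon. It involves neither bromo nor fluoro, so it gives no direction for this change. No change beyond the scatter is therefore expected in this assay. The expected step is a 1.1-fold lower number from compound 2 to compound 4 (0.04 log units; within the scatter). For compound 4 the estimated value is 95 mg/kg, with an expected range from 48 mg/kg to 190 mg/kg.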

Compound 4, dose for half-maximal effect: 43.4 mg/kg
The estimate for compound 4 lay 2.2-fold (0.34 log units) above the measured number; the whole stated range lies above it.
By their numbers in this assay, from the lowest: compounds 1, 4, 3 and 2 (each within the scatter of the next, the first and the last beyond it).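

In this assay, replacing the 4-bromophenyl with the 4-fluorophenyl gives a 2.4-fold lower number from compound 2 to compound 4 (0.38 log units; beyond the scatter). This position, para to a large group, therefore responds to an exchange of one heavy atom for another, with no change in the counted hydrogen-bond donors or acceptors, whereas the earlier step concerned only methoxy and hydrogen. Nothing available here explains this step.

As far as these compounds go, whether chloro, trifluoromethyl or an amine at this position would follow bromo or fluoro remains open. It is also unknown whether fluoro would give a similar step in a compound carrying several methoxy groups on that ring.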